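The compounds below may be only part of what the source reports. "The series", "measured", "known", "first", "only" and "open" are said of these compounds alone.

The measured compounds:

Compound 1, `O=C1C(NC2CCCC2)=CC(=O)c2c1nc1n2[C@H]2OC[C@@H](O)[C@H]2OC1`: in a functional assay on MGC-803 cells (Homo sapiens) for inhibition, read by sulforhodamine B assay (a higher number here means a weaker inhibitor, a lower number a stronger inhibitor), compound 1 gives > 16000 nM, which is a limit of the assay and not a number.
Compound 2, `O=C1C=C(Nc2cccc(F)c2)C(=O)c2c1nc1n2[C@H]2OC[C@@H](O)[C@H]2OC1`: compound 2 gives 2180 nM.
Compound 3, `COc1cccc(NC2=CC(=O)c3nc4n(c3C2=O)[C@H]2OC[C@@H](O)[C@H]2OC4)c1`: compound 3 gives 1780 nM.

Compounds 2 and 3 both carry an arylamino group on the shared core, and the step of a 1.2-fold lower number from compound 2 to compound 3 (0.09 log units; within the scatter) shows that this change made no difference beyond the scatter. Compound 1, with cyclopentylamino in that position, stands apart: its result is known only as a limit, so it is the weakest of the three, since the limit of > 16000 nM in this assay, at which 1 of the 3 values shown sits, places it beyond the range the assay resolves.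

Compound 4, `CCCN(CCC)C1=CC(=O)c2c(nc3n2[C@H]2OC[C@@H](O)[C@H]2OC3)C1=O`, is not yet measured. It differs from compound 1 by dipropylamino in place of cyclopentylamino on a double-bonded ring carbon. Within the data shown here, no measured step involves a change of this kind; the only measured step, from an arylamino pair, does not bear on it. With compound 1 sitting at a limit, compound 4 is expected to remain weak, and the step that the limit leaves unreadable from compound 1 to compound 4 is estimated to stay within the scatter. Compound 4 is therefore expected to give about 20000 nM, likely between 5000 nM and 80000 nM, with a real chance that only a limit is reported.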

Compound 4, half-maximal inhibitory concentration: > 16000 nM
Compound 4: a limit, no number (the forecaster's own chance of this, stated with the estimate: 65%); the middle value does not contradict the limit.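

Compound 4, like compound 1, reads only as a limit of the assay, and no step from compound 1 to compound 4 can be read: the limit of > 16000 nM in this assay, at which 2 of the 4 values shown sit.

The compounds shown leave open whether dipropylamino and cyclopentylamino differ at all in this assay.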